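A Side-Chain Swap on an Amide

The source may hold more compounds than are shown below. What is called first, only, known or untested is meant among the compounds shown, and "the series" means these compounds.

Of the compounds shown here, three built on one shared core have been tested in an assay on isolated protein for inhibition of tyrosine-protein kinase Fes/Fps (Homo sapiens), read by HTRF, tested at 10 uM; a higher number here means more inhibition at the concentration tested (going by the name of the read-out), a lower number less inhibition. Compound 1 `Cc1cccc(Oc2ccnc(N3CCC[C@H]3C(=O)NCc3cccnc3)n2)c1` gives 5%. Compound 2 `Cc1cccc(Oc2ccnc(N3CCN(C(=O)c4c(C)noc4C)CC3)n2)c1` gives 7%, and compound 3 `COC[C@@H]1CCCN1C(=O)[C@@H]1CCCN1c1cc(Nc2cccc(OC)c2)nc(N)n1` gives 8%. These three numbers lie within the usual scatter of one another, so none can be set apart from the others, and each shows little inhibition at the concentration tested. Compound 4 `COC(=O)C(CO)NC(=O)[C@@H]1CCCN1c1nccc(Oc2cccc(C)c2)n1` has not yet been measured. It differs from compound 1 by 2-hydroxy-1-(methoxycarbonyl)ethyl in place of (pyridin-3-yl)methyl on an amide-type nitrogen. Among the compounds with values here, no measured pair isolates such a change, so the expectation rests only on the narrow spread seen so far. The expected step is a number 1 percentage points higher from compound 1 to compound 4 (within the scatter), nothing beyond the scatter. Compound 4 is therefore estimated at 6%, with a range from -5% to 20%.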

Compound 4, a percentage reported as inhibition, at one concentration (the size of the read-out at that concentration, not a potency): 0%
For compound 4 the middle estimate is 6 percentage points above the measured one, within the range that was stated.
By their numbers in this assay, from the lowest: compounds 4, 1, 2 and 3 (each within the scatter of the next).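

Within the data shown here, the step of a number 5 percentage points lower from compound 1 to compound 4 (within the scatter) in this assay is the first direct reading on this amide-type nitrogen. Exchanging (pyridin-3-yl)methyl, with its aromatic ring, for the ring-free 2-hydroxy-1-(methoxycarbonyl)ethyl therefore leaves the read-out within the scatter, and both compounds show little inhibition. Nothing available explains this result. Still open, as far as these compounds go, is whether a carboxylic acid in place of the methoxycarbonyl, or a plain butyl chain on this nitrogen, would give a clearly different number. Any such group could also stay at a similarly low level.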